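Dropping the Fluoro Group: What to Expect for Compound 4

This account rests on a few compounds, and the source may have more. Where it says the series, first, only, none or still open, it means among the compounds named here.

Three compounds sharing one core, and differing only in the ring attached to the thiocarbonyl carbon, have been tested in a functional assay on A-431 cells (Homo sapiens) for cytotoxicity, read by MTT assay, with a stated time of 72 h, tested at 100 uM; a lower number here means less inhibition of growth, a higher number more inhibition of growth at the concentration tested. Compound 1 `N/C(=N\NC(=S)N1CCCC1)c1ccc(F)cn1` gives 85.6% in this assay. Compound 2 `N/C(=N\NC(=S)N1CCSCC1)c1ccc(F)cn1` gives 86.6%, and compound 3 `N/C(=N\NC(=S)N1CCOCC1)c1ccc(F)cn1` gives 85.6%. The steps among them are small: a number 1 percentage points higher from compound 1 to compound 2 (within the scatter), no change at the digits printed from compound 1 to compound 3 (within the scatter) and a number 1 percentage points lower from compound 2 to compound 3 (within the scatter). Compound 1 thus sits level with compound 3 at the digits shown, the two together the lowest of the three numbers, with compound 2 the furthest away, and every gap lies within the scatter.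

Compound 4 `N/C(=N\NC(=S)N1CCCC1)c1ccccn1` differs from compound 1 by hydrogen in place of fluoro on an aromatic carbon. Among the compounds with values here, none of the measured steps touches this part of the molecule; all of them swap the ring on the thiocarbonyl carbon, and none moves the number beyond the scatter. So there is no direct guide for the loss of the fluoro group, only the observation that all three measured compounds sit at much the same high level. Compound 4 is therefore estimated at 82%, with a range from 68% to 92%. This amounts to an expected step of a number 3.6 percentage points lower from compound 1 to compound 4 (within the scatter), likely within the scatter.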

Compound 4, percent growth inhibition at one concentration: 83.8%
For compound 4 the middle estimate is 1.8 percentage points below the measured one; the range from low to high includes it.
By their numbers in this assay, from the lowest: compounds 4, 1, 3 and 2 (each within the scatter of the next).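

In this assay, the change to hydrogen in place of fluoro on an aromatic carbon, para to a large group, gives a number 1.8 percentage points lower from compound 1 to compound 4 (within the scatter). Within the data shown here, this is the first step at this position of the shared core, and like the ring swaps on the thiocarbonyl carbon, it stays within the scatter, so with the pyrrolidin-1-yl ring in place, the fluoro group is not needed to keep growth inhibition high at the concentration tested. No supporting measurement bears on why the number holds when the fluoro group leaves.

Only hydrogen and fluoro are shown at this position, so it remains open whether an amine, a methoxy group or a carboxylic acid there would move the number beyond the scatter. As far as these compounds go, it is also open whether the same change would hold with the morpholin-4-yl or thiomorpholin-4-yl ring in place.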